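This account rests on a few compounds, and the source may have more. Where it says the series, first, only, none or still open, it means among the compounds named here.

Measured so far:
- compound 1 `O=[N+]([O-])c1cccc(/N=N/N2CCCC2)c1` — 80000 nM
- compound 2 `FC(F)(F)c1cccc(N/N=N/c2ccccc2)c1` — 15000 nM

In an ADME assay on Vero cells (Chlorocebus sabaeus) for cytotoxicity, read by crystal violet staining (a higher number here means that more compound is tolerated, a lower number that less compound is tolerated), compound 1 gives 80000 nM, the highest of the two numbers recorded. Its nearest neighbour is compound 2, which in this assay gives 15000 nM; compound 2 sits at the lower number, and the gap between the two is beyond the scatter. For the measured compounds named here, no pair of measured compounds differing in one place is available, so there is no step to lean on.

Compound 3 `Clc1cccc(/N=N/N2CCCC2)c1` has not been measured in this assay. Compared with compound 1, the change is chloro in place of nitro on an aromatic carbon. Going by the values given here, with no measured step of this kind to go by, the step is taken as small: the change from compound 1 to compound 3 is expected to be a 1.6-fold lower number from compound 1 to compound 3 (0.20 log units; within the scatter), most likely within the scatter or slightly downward. For compound 3 the expected value is 50000 nM, in a range from 15000 nM to 150000 nM.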

Compound 3, half-maximal cytotoxic concentration: >= 100000 nM
Compound 3 gave a limit, no number (the forecaster's own chance of this, stated with the estimate: 20%); at least 2.0-fold (0.30 log units) between middle value and limit.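

In this assay compound 3 gives >= 100000 nM, which is a limit of the assay and not a number. Chloro in place of nitro on this aromatic carbon gives the first step in the series at a single position: an at least 1.2-fold higher number from compound 1 to compound 3 (0.09 log units; that floor lies within the scatter). The nitro group is therefore not needed at this position for the number to stay at this high level, although the floor of the step does not by itself separate the two compounds.

From the compounds shown here alone, how far the true value of compound 3 lies past the limit remains open, and so does the real size of the step. Also open, going by these compounds, is whether an amine or a carboxylic acid on the same aromatic carbon would hold the number at this level in this assay.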